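Dropping the Methoxy from a Thiazole Amide

The source may hold more compounds than are shown below. What is called first, only, known or untested is meant among the compounds shown, and "the series" means these compounds.

compound 1, `O=C(NCc1ccccc1)c1csc(-c2c[nH]c3ccccc23)n1`: 9510 nM
compound 2, `COc1ccc(NC(=O)c2csc(-c3cn(Cc4ccc(Cl)cc4)c4ccccc34)n2)cc1`: > 100000 nM

In a functional assay on HeLa cells (Homo sapiens) for cytotoxicity, read by MTT assay, with a stated time of 48 h, in the absence of a further agent (on this read-out higher numbers stand for weaker inhibition and lower numbers for stronger inhibition), compound 1 gives 9510 nM. For compound 2 the assay reports only a limit, > 100000 nM, which is the limit of > 100000 nM in this assay, at which 1 of the 2 values shown sits. Compound 2 therefore stands at the weak end of the two numbers shown; no measured step connects it to compound 1. Compound 3, `O=C(Nc1ccccc1)c1csc(-c2cn(Cc3ccc(Cl)cc3)c3ccccc23)n1`, differs from compound 2 by hydrogen in place of methoxy on an aromatic carbon. Among the measured compounds shown here, no measured step between related compounds is available, so the expectation for compound 3 is that it stays near the limit of this assay, and the step of a number no higher from compound 2 to compound 3 (the limit leaves the size open) is expected to be no larger than the usual scatter. Compound 3 is estimated at 100000 nM, within 30000 nM to 300000 nM.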

Compound 3, half-maximal inhibitory concentration: 24300 nM
The estimate for compound 3 lay 4.1-fold (0.61 log units) above the measured number, and the stated range ends above it.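

In this assay, hydrogen in place of methoxy on the aromatic ring gives an at least 4.1-fold lower number from compound 2 to compound 3 (0.61 log units; beyond the scatter), so this position on the anilide ring does affect the read-out and a methoxy there goes with weaker inhibition. Only the lower bound of that change is known. The value of compound 2 is a limit, not a number: the limit of > 100000 nM in this assay, at which 1 of the 3 values shown sits.

On these data alone, what an amine or a hydroxyl group at this same place would give stays open. So does whether removing the methoxy would have a similar effect on a compound with a different core.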